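This account rests on a few compounds, and the source may have more. Where it says the series, first, only, none or still open, it means among the compounds named here.

Working notes on the aryl ether series.

Compound 1 `Cc1nnsc1CO/N=C/c1c(C)nn(C)c1Oc1ccccc1Cl` gives 42500 nM in a functional assay on HCT-116 cells (Homo sapiens) for inhibition, read by MTT assay, with a stated time of 48 h; on this read-out higher numbers stand for weaker inhibition and lower numbers for stronger inhibition. Compound 2 `Cc1nnsc1CO/N=C/c1c(C)nn(C)c1Oc1cccc(F)c1` reaches only the limit of this assay, > 50000 nM. Among the compounds with values here, the single measured step, an at least 1.1-fold higher number from compound 1 to compound 2 (0.07 log units; that floor lies within the scatter), is a floor and nothing more; it cannot be sized further because the limit of > 50000 nM in this assay, at which 1 of the 2 values shown sits, is all that is known for compound 2.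

Compound 3 `Cc1nnsc1CO/N=C/c1c(C)nn(C)c1Oc1cccc(C(F)(F)F)c1` differs from compound 2 by trifluoromethyl in place of fluoro on an aromatic carbon. Compound 2 stands at the limit, so no resolved number anchors this step. Within the data shown here, the only measured step, the one from compound 1 to compound 2, lies within the scatter, and it bears on this step only by showing that a change on the aryl ether left the read-out essentially unchanged. No step beyond the scatter is expected in this assay. Compound 3 is therefore expected at 60000 nM, within a range of 25000 nM to 150000 nM, the estimated step being a step that the limit leaves unreadable from compound 2 to compound 3.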

Compound 3, half-maximal inhibitory concentration: 10300 nM
Compound 3: the middle estimate sits 5.8-fold (0.77 log units) above what was measured; measured number below the stated range.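

In this assay, within the data shown here, trifluoromethyl in place of fluoro on an aromatic carbon gives an at least 4.8-fold lower number from compound 2 to compound 3 (0.68 log units; beyond the scatter) and so provides the first step beyond the scatter. The position meta to a large group therefore responds to the group it carries, which the earlier step from compound 1 to compound 2 could not show, as that step stayed within the scatter. The size of the new step remains a floor, because compound 2 stands at a limit: the limit of > 50000 nM in this assay, at which 1 of the 3 values shown sits.

As far as these compounds go, whether the lower number is specific to trifluoromethyl or would also follow from a group such as nitrile, methoxy or an amine at this place stays open. Also open, from the compounds shown here alone, is how the read-out would respond to trifluoromethyl at another place on the same ring.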